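Exchanging a fluorinated aryl substituent: compound 2 to compound 3

The compounds below may be only part of what the source reports. "The series", "measured", "known", "first", "only" and "open" are said of these compounds alone.

Measured so far in a functional assay on CWR22R cells (Homo sapiens) for antiproliferative activity, read by propidium iodide staining, with a stated time of 96 h; a higher number here means a weaker inhibitor, a lower number a stronger inhibitor:

compound 1 `CC(O)(COc1cccc(S(F)(F)(F)(F)F)c1)C(=O)Nc1cc(C(F)(F)F)cc(C(F)(F)F)c1` gives 2300 nM
compound 2 `CC(O)(CS(=O)(=O)c1ccc(S(F)(F)(F)(F)F)cc1)C(=O)Nc1ccc(S(F)(F)(F)(F)F)cc1` gives 17300 nM

Of these two numbers, compound 2 has the higher, at 17300 nM, and compound 1 stands lower at 2300 nM, a gap beyond the scatter. The two compounds differ in more than one place, so this gap does not isolate the effect of any single change.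

The next compound is compound 3 `CC(O)(CS(=O)(=O)c1ccc(C(F)(F)F)cc1)C(=O)Nc1ccc(S(F)(F)(F)(F)F)cc1`. Its structure departs from compound 2 by one change: a group of 4 heavy atoms (1 carbon, 3 fluorine; no ring) in place of a group of 6 heavy atoms (5 fluorine, 1 sulfur; no ring), on an aromatic carbon. A trifluoromethyl takes the place of the group of 6 heavy atoms, on an aromatic carbon of a six-membered aromatic ring of carbon only, para to a large group.

Within the data shown here, no measured step covers this exchange, so its size in this assay remains open. Among the measured compounds shown here, the only close reference is compound 2 at 17300 nM, and no change beyond the scatter is expected from it, with at most a slight move to a lower number. The expected result is a 1.4-fold lower number from compound 2 to compound 3 (0.16 log units; within the scatter). For compound 3 the estimated value is 12000 nM, with an expected range of 4000 nM to 30000 nM.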

Compound 3, half-maximal inhibitory concentration: 28900 nM
For compound 3 the middle estimate is 2.4-fold (0.38 log units) below the measured one; low and high end bracket the measured number.
By their numbers in this assay, from the lowest: compound 1; then compounds 2 and 3 (each within the scatter of the next).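

In this assay, among these compounds, the first step that isolates a single change is trifluoromethyl in place of the group of 6 heavy atoms (5 fluorine, 1 sulfur), on an aromatic carbon para to a large group, and it reads a 1.7-fold higher number from compound 2 to compound 3 (0.22 log units; within the scatter). With the rest of the compound held fixed, the two groups therefore cannot be told apart at this position in this assay, a finding that applies only to this pair and leaves the other aryl substituent of the shared core untouched. No available evidence bears on the reason for this outcome.

As far as these compounds go, whether a position that accepts these two fluorinated groups without a change beyond the scatter would behave the same way with a nitrile, a methoxy group or a plain hydrogen remains open. Among the compounds shown here, the gap between compound 1 and the other two compounds also remains unassigned, since no single-change step connects compound 1 to them, so the separate contributions of its ether link and its anilide substituents are unknown.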